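Imine and cyclic amide series: a methoxy step repeated

This account rests on a few compounds, and the source may have more. Where it says the series, first, only, none or still open, it means among the compounds named here.

Compound 1 `COc1cc(/C=N/c2c(C#N)ncn2-c2ccc(F)cc2)cc(OC)c1OC` and compound 2 `COc1ccc(/C=N/c2c(C#N)ncn2-c2ccc(F)cc2)cc1OC` share one core; compound 3 `COc1ccc(C2N=C(C(N)=O)c3ncn(-c4ccc(F)cc4)c3N2)cc1` and compound 4 `COc1ccc(C2N=C(C(N)=O)c3ncn(-c4ccc(F)cc4)c3N2)cc1OC` share another, and the difference between the two cores is not broken down here. In a functional assay on T47D cells (Homo sapiens) for antiproliferative activity, read by MTT assay, with a stated time of 48 h (a lower number here means a stronger inhibitor, a higher number a weaker inhibitor), compound 2 gives 7230 nM and compound 1 gives 13700 nM, so that a 1.9-fold higher number from compound 2 to compound 1 (0.28 log units; within the scatter) is the step made by methoxy in place of hydrogen on an aromatic carbon. Compound 3 gives 5870 nM in this assay, which stands within the scatter of compound 2 and beyond it only against compound 1. Compound 4 has not been measured; it differs from compound 3 by methoxy in place of hydrogen on an aromatic carbon. This is the same kind of change as that from compound 2 to compound 1, not the same: around the place in compound 1 the entering group is also meta to a methoxy group, which is not so in compound 4. On the earlier step alone, a number for compound 4 somewhat higher than that of compound 3 is expected, and a 1.4-fold higher number from compound 3 to compound 4 (0.16 log units; within the scatter) is the estimated step, set a little below the earlier one because the step of a 1.9-fold higher number from compound 2 to compound 1 (0.28 log units; within the scatter) itself lay within the scatter. Compound 4 is thus estimated at 8500 nM in this assay, with an expected range from 4000 nM to 18000 nM.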

Compound 4, half-maximal inhibitory concentration: 9960 nM
The estimate for compound 4 lay 1.2-fold (0.07 log units) below the measured number; measured number inside the range.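

In this assay, methoxy in place of hydrogen on an aromatic carbon gives a 1.7-fold higher number from compound 3 to compound 4 (0.23 log units; within the scatter). Set beside the step on the other core, the new step agrees with it: the same change on two cores in this assay, a 1.9-fold higher number (0.28 log units; within the scatter) from compound 2 to compound 1 and a 1.7-fold higher number (0.23 log units; within the scatter) from compound 3 to compound 4, 1.1-fold (0.05 log units) apart, within the scatter of two such steps. Neither step lies beyond the scatter, so the two pairs support carrying the change between these two cores as a small step of similar size, but they do not establish a real loss of activity from the methoxy group on either core, or show what the change would do on a third core.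

At this place the compounds shown carry only hydrogen or methoxy, so a hydroxyl group, a chlorine atom or a longer ether such as ethoxy remains open. The fluorine stays the same in all four compounds, which leaves open how hydrogen or an amine in its place would read, and whether either step would hold in another cell line.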